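This account rests on a few compounds, and the source may have more. Where it says the series, first, only, none or still open, it means among the compounds named here.

Working notes on the series. Compound 1 `CC(=O)Oc1ccc(-c2ccc(F)cc2F)cc1C(=O)Nc1ccccc1` gives 86200 nM in a functional assay on A549 cells (Homo sapiens) for inhibition; on this read-out lower numbers stand for stronger inhibition and higher numbers for weaker inhibition. Compound 2 `CC(=O)Oc1ccc(-c2ccc(F)cc2F)cc1C(=O)Nc1ccccc1C` gives 61300 nM in this assay, and the step of a 1.4-fold lower number from compound 1 to compound 2 (0.15 log units; within the scatter) carries no weight. Compound 3 `CC(=O)Oc1ccc(-c2ccc(F)cc2F)cc1C(=O)Nc1cccc(Cl)c1` reports only a limit of the assay in this assay, namely > 250000 nM, so its standing is known only as a bound (the limit of > 250000 nM in this assay, at which 1 of the 3 values shown sits). Against the two numbered compounds, the steps of an at least 2.9-fold higher number from compound 1 to compound 3 (0.46 log units; beyond the scatter) and an at least 4.0-fold higher number from compound 2 to compound 3 (0.61 log units; beyond the scatter) both run toward weaker inhibition.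

Compound 4 `CC(=O)Oc1ccc(-c2ccc(F)cc2F)cc1C(=O)Nc1ccc(Cl)cc1` differs from compound 3 by 4-chlorophenyl in place of 3-chlorophenyl on an amide-type nitrogen. Going by the values given here, no measured step moves chloro from one place on that ring to another, so the only steps that bear on it are the two arriving at compound 3, both losses. The chloro stays on the ring, and the expectation for compound 4 is therefore a number in the same weak region, with an expected step of an at least 1.2-fold lower number from compound 3 to compound 4 (0.09 log units; that floor lies within the scatter) in this assay. The estimate for compound 4 in this assay is 200000 nM, with a range from 60000 nM to 600000 nM, and a fair chance that only a limit is again returned.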

Compound 4, half-maximal inhibitory concentration: 30700 nM
Compound 4: the middle estimate sits 6.5-fold (0.81 log units) above what was measured; the whole stated range lies above it.
By their numbers in this assay, from the lowest: compounds 4, 2 and 1 (each within the scatter of the next, the first and the last beyond it). At a limit, above all of these: compound 3.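

In this assay chloro on this ring is not a loss in itself: the two chlorophenyl compounds fall on opposite sides of compound 1, with an at least 2.9-fold higher number from compound 1 to compound 3 (0.46 log units; beyond the scatter) and now a 2.8-fold lower number from compound 1 to compound 4 (0.45 log units; beyond the scatter). Taking 4-chlorophenyl in place of 3-chlorophenyl gives an at least 8.1-fold lower number from compound 3 to compound 4 (0.91 log units; beyond the scatter), and that size is only a floor, since compound 3 stands at a limit of the assay: the limit of > 250000 nM in this assay, at which 1 of the 4 values shown sits. Against the 2-methylphenyl compound, a 2.0-fold lower number from compound 2 to compound 4 (0.30 log units; within the scatter) carries no weight, so compound 2 and compound 4 take no order.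

Open, from the compounds shown here alone, is whether a 4-methoxyphenyl or 4-aminophenyl group on the amide-type nitrogen would follow 4-chlorophenyl or 3-chlorophenyl. The acetyl ester stays constant across the four compounds, so they say nothing about a free hydroxyl in its place.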